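The source may hold more compounds than are shown below. What is called first, only, known or untested is meant among the compounds shown, and "the series" means these compounds.

Compound 1 `O=C(Nc1cccc(-c2nc(-c3ccc(NC(=O)c4cccnc4)cc3Cl)no2)c1)c1ccccc1` — a functional assay on MDA-MB-231 cells (Homo sapiens) for antiproliferative activity, read by MTT assay, with a stated time of 72 h; a higher number here means a weaker inhibitor, a lower number a stronger inhibitor: 12800 nM
Compound 2 `O=C(Nc1ccc(-c2noc(-c3cccc(NS(=O)(=O)c4ccccc4)c3)n2)c(Cl)c1)c1cccnc1` — this assay : > 10000 nM, a limit of the assay, not a number.
Compound 3 `COc1cccc(S(=O)(=O)Nc2cccc(-c3nc(-c4ccc(NC(=O)c5cccnc5)cc4Cl)no3)c2)c1` — this assay : > 10000 nM, likewise a limit and not a number.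

Compound 3 thus stands at the limit of > 10000 nM in this assay, at which 2 of the 3 values shown sit, and no number is available for it. The steps a step that the limit leaves unreadable from compound 1 to compound 2 and a step that the limit leaves unreadable from compound 1 to compound 3 cannot be read in size, and the step that the two limits leave unreadable from compound 2 to compound 3 is unreadable at both ends. Compound 4 `CC(=O)Nc1ccc(S(=O)(=O)Nc2cccc(-c3nc(-c4ccc(NC(=O)c5cccnc5)cc4Cl)no3)c2)cc1C` differs from compound 3 by 4-acetamido-3-methylphenyl in place of 3-methoxyphenyl on a sulfonyl sulfur. Going by the values given here, no measured step gives a readable size for a change on this sulfonyl sulfur, so nothing points to a move back below the limit. Compound 4 is therefore expected to remain weak, with an estimated value of 15000 nM (range 5000 nM to 45000 nM), and the expected step that the limit leaves unreadable from compound 3 to compound 4 is taken as none beyond the scatter.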

Compound 4, half-maximal inhibitory concentration: > 10000 nM
Compound 4: only a limit was reported; the forecaster's own chance of this, stated with the estimate: 70%; the middle value does not contradict the limit.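

Compound 4 gives only a limit in this assay, and the steps to it from compound 2 and compound 3 cannot be read: the limit of > 10000 nM in this assay, at which 3 of the 4 values shown sit.

The compounds shown leave open how large any change on the sulfonyl sulfur is, with a number for compound 1 alone.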